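This account rests on a few compounds, and the source may have more. Where it says the series, first, only, none or still open, it means among the compounds named here.

Measured so far in a functional assay on PC-3 cells (Homo sapiens) for cytotoxicity, read by MTT assay, with a stated time of 72 h; a lower number here means a stronger inhibitor, a higher number a weaker inhibitor:

- compound 1 `COc1ccc(/C=C/C(=O)CC(C)=O)cc1`: 15800 nM
- compound 2 `COc1ccc(/C=C/c2cc(C)no2)cc1`: > 100000 nM
- compound 3 `Cc1cc(/C=C/c2ccc(O)cc2)on1`: 50200 nM

Compound 2 sits at a limit of this assay, (the limit of > 100000 nM in this assay, at which 1 of the 3 values shown sits); its value is not a number. Compound 3 carries the same core as compound 2 with hydrogen in place of methyl on an oxygen on an aromatic ring, and that change gives an at least 1.9-fold lower number from compound 2 to compound 3 (0.29 log units; that floor lies within the scatter). Compound 1 stands on a different core; how the two cores differ is not broken down here. Against compound 3 it shows the lower number, by a gap beyond the usual scatter.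

Compound 4 `CC(=O)CC(=O)/C=C/c1ccc(O)cc1` is not yet measured. It is made from compound 1 by the same change as from compound 2 to compound 3: hydrogen in place of methyl on an oxygen on an aromatic ring, at a place described in the same words. For the measured compounds named here, the only measured instance of this change rests on a limit, so its true size is not pinned down; only a floor is known, and that floor lies within the scatter.

On that footing, compound 4 is expected to come out near compound 1 or somewhat lower, with the step estimated as a 1.8-fold lower number from compound 1 to compound 4 (0.24 log units; within the scatter), a direction taken from an at least 1.9-fold lower number from compound 2 to compound 3 (0.29 log units; that floor lies within the scatter). For compound 4 in this assay the estimate is 9000 nM, with a range from 3000 nM to 30000 nM.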

Compound 4, half-maximal inhibitory concentration: 20200 nM
Estimate against measurement, compound 4: 2.2-fold (0.35 log units) below, and the stated range covers the measured number.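

On the core of compound 1, methoxy to hydroxy gives a 1.3-fold higher number from compound 1 to compound 4 (0.11 log units; within the scatter) in this assay, so the step shows no readable effect of the change on this core. Set beside the earlier instance, this result neither confirms that the change carries from one core to the other nor shows that the two cores respond differently: the same change on two cores in this assay, an at least 1.9-fold lower number (0.29 log units; that floor lies within the scatter) from compound 2 to compound 3 and a 1.3-fold higher number (0.11 log units; within the scatter) from compound 1 to compound 4; the limit leaves it open whether they differ Compound 2 sits at a limit and its value is not a number, so the earlier step has a floor but no fixed size, and that floor does not settle its direction beyond the scatter: the limit of > 100000 nM in this assay, at which 1 of the 4 values shown sits.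

The compounds shown carry only methoxy or hydroxy at this place on the aromatic ring, so the outcome with an amine, a fluorine atom or a longer alkoxy chain such as ethoxy in their stead remains open. Also open, as far as these compounds go, is whether methoxy to hydroxy would give a step of readable size on a further core, with a number rather than a limit at both ends, which is what a real test of carrying this change across cores would need.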